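From hydroxy to methoxy on compound 3

The source may hold more compounds than are shown below. What is called first, only, known or untested is meant among the compounds shown, and "the series" means these compounds.

Three close relatives have been tested in a functional assay on MGC-803 cells (Homo sapiens) for antiproliferative activity, read by CellTiter-Glo, with a stated time of 72 h; a higher number here means a weaker inhibitor, a lower number a stronger inhibitor. There, compound 1 `O=C(NO)c1cccc(/C=C/c2ccnc(-c3ccccc3O)c2)c1` gives 2810 nM, compound 2 `O=C(NO)c1ccc(/C=C/c2ccnc(-c3cc(F)ccc3O)c2)cc1` gives 1920 nM and compound 3 `O=C(NO)c1ccc(/C=C/c2ccnc(-c3ccccc3O)c2)cc1` gives 1420 nM. Compound 3 lies within the usual scatter of both of the others, so these three numbers cannot be ranked with any confidence.

The next compound to be tested is compound 4 `COc1ccccc1-c1cc(/C=C/c2ccc(C(=O)NO)cc2)ccn1`. It turns the 2-hydroxyphenyl group of compound 3 into a 2-methoxyphenyl group: methyl in place of hydrogen on an oxygen on an aromatic ring. The hydrogen on that oxygen is simply replaced by a methyl.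

Among the measured compounds shown here, only one measured step bears on this, and only indirectly. That step, a 1.4-fold lower number from compound 2 to compound 3 (0.13 log units; within the scatter), swaps fluoro for hydrogen on an aromatic carbon and is small enough to sit within the scatter. For the measured compounds named here, it leaves the hydroxy group untouched, and no measured pair changes that group, so the data give no firm direction for the new step. The expected step is a 1.4-fold higher number from compound 3 to compound 4 (0.15 log units; within the scatter), a cautious lean towards a higher number that would not exceed the scatter. For compound 4 the estimated value is 2000 nM, with an expected range of 700 nM to 5500 nM.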

Compound 4, half-maximal inhibitory concentration: 6350 nM
The estimate for compound 4 lay 3.2-fold (0.50 log units) below the measured number, and the stated range ends below it.
By their numbers in this assay, from the lowest: compounds 3, 2 and 1 (each within the scatter of the next); then compound 4.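

Placing a methyl on the oxygen of the 2-hydroxyphenyl group gives a 4.5-fold higher number from compound 3 to compound 4 (0.65 log units; beyond the scatter) in this assay. Among the compounds shown here, this is the first change to move the number beyond the scatter, whereas the only earlier measured step, on a ring carbon, stayed within it. Compound 4 also separates from the fluorinated relative, with a 3.3-fold higher number from compound 2 to compound 4 (0.52 log units; beyond the scatter), so among these compounds the hydroxy position is the one place where a single edit shows a clear loss of antiproliferative strength, and nothing available explains why the methyl has this effect.

The compounds shown carry only hydrogen or methyl on that oxygen, so one comparison cannot tell whether the hydrogen itself matters or whether any added group would raise the number; an ethyl group on the oxygen, or an amine in place of the hydroxy, would help separate these two readings. From the compounds shown here alone, it also remains open whether the same methyl step would raise the number to a similar degree on compound 1 or compound 2, which both still carry the hydroxy group.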